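The compounds below may be only part of what the source reports. "The series", "measured", "known", "first", "only" and "open" are said of these compounds alone.

Measured compounds in an assay on isolated protein for inhibition of Fatty-acid amide hydrolase 1 (Homo sapiens); on this read-out lower numbers stand for stronger inhibition and higher numbers for weaker inhibition:

Compound 1 `O=C(CCCCCCc1ccccc1)c1nnn[nH]1` gives > 1000 nM, a limit of the assay and not a number.
Compound 2 `CCCCCCCC/C=C\CCCCCCC(=O)c1nc(-c2ccccc2)c(-c2ccccc2)o1` gives > 100000 nM, a limit of the assay and not a number.
Compound 3 `CCCCCCCC/C=C\CCCCCCC(=O)c1nc2ccc(C)cc2o1` gives > 100000 nM, a limit of the assay and not a number.

Compound 2 stands at the limit of > 100000 nM in this assay, at which 2 of the 3 values shown sit; no number is known for it, only that any inhibition constant lies beyond that limit. Compound 3 sits at the same limit. Compound 1 sits at the limit of > 1000 nM in this assay, at which 1 of the 3 values shown sits, a different limit, so the three values cannot be ordered against one another. Going by the values given here, no pair of measured compounds differs in a single place, and so no size of step has been observed anywhere.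

Compound 4 `CCCCCCCC/C=C\CCCCCCC(=O)c1ncc(-c2ccccc2)o1` differs from compound 2 by hydrogen in place of phenyl on an aromatic carbon. Nothing measured shows what this change does in this assay. Going by these compounds, because compound 2 sits at the limit of > 100000 nM in this assay, at which 2 of the 3 values shown sit, the starting point itself is unknown, and the expected step that the limit leaves unreadable from compound 2 to compound 4 is none beyond the scatter. Compound 4 is therefore estimated at 150000 nM, within 20000 nM to 1000000 nM, most likely reported again as a limit rather than a number.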

Compound 4, inhibition constant: 320 nM
The estimate for compound 4 lay 470-fold (2.67 log units) above the measured number; the whole stated range lies above it.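

In this assay, hydrogen in place of phenyl on an aromatic carbon, next to the ring nitrogen, gives an at least 310-fold lower number from compound 2 to compound 4 (2.49 log units; beyond the scatter). Going by these compounds alone, this is the only readable step, and it shows that this carbon of the five-membered aromatic ring is highly sensitive to substitution: with the other phenyl group and the rest of the structure unchanged, phenyl at this carbon separates a measurable inhibition constant from a limit of the assay. The true size of the step remains open-ended because compound 2 carries a limit and not a number: the limit of > 100000 nM in this assay, at which 2 of the 4 values shown sit.

The compounds shown do not reveal whether a methyl group, a chlorine atom, an amine or a carboxylic acid at this carbon would keep the inhibition seen with compound 4, so the change cannot yet be tied to anything beyond the loss of phenyl. They also leave open what the phenyl retained in compound 4 contributes, and whether hydrogen at that carbon or a shorter chain on the carbonyl would move the value in either direction.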